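The source may report more compounds than this note shows. Statements on the series, on what has been measured and on what is new or still open speak of the compounds shown alone.

Measured so far in a functional assay on A549 cells (Homo sapiens) for antiproliferative activity, read by MTT assay, with a stated time of 72 h; a higher number here means a weaker inhibitor, a lower number a stronger inhibitor:
- compound 1 `COc1ccc(N2CCN(C(=S)SCc3ccc4nc(N)nc(N)c4c3)CC2)cc1`: 1590 nM
- compound 2 `Nc1nc(N)c2cc(CSC(=S)N3CCN(c4ccccc4F)CC3)ccc2n1`: 6460 nM

Compound 2 holds the higher of the two numbers in this assay, so it is the weaker inhibitor of the pair. The next compound is compound 3 `Nc1nc(N)c2cc(CSC(=S)N3CCN(c4ccccc4[N+](=O)[O-])CC3)ccc2n1`, with the change nitro in place of fluoro on an aromatic carbon, ortho to a large group, or 2-fluorophenyl to 2-nitrophenyl. Among the measured compounds shown here, one measured step bears on this, the modest 4.1-fold higher number from compound 1 to compound 2 (0.61 log units; beyond the scatter), which also alters the substituted phenyl group. That step involves no nitro group, so the data hold no direct measure of this swap. No firm direction can be drawn from it, and a small step, possibly within the scatter, is expected. The expected change is a 1.3-fold lower number from compound 2 to compound 3 (0.11 log units; within the scatter). Compound 3 is estimated at 5000 nM, with an expected range of 1600 nM to 15000 nM.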

Compound 3, half-maximal inhibitory concentration: 4360 nM
The estimate for compound 3 lay 1.1-fold (0.06 log units) above the measured number, within the range that was stated.
By their numbers in this assay, from the lowest: compound 1; then compounds 3 and 2 (each within the scatter of the next).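

In this assay, nitro in place of fluoro on an aromatic carbon, ortho to a large group, gives a 1.5-fold lower number from compound 2 to compound 3 (0.17 log units; within the scatter), so this direct swap does not separate the two groups at this position. The 2-nitrophenyl group also leaves a 2.7-fold higher number from compound 1 to compound 3 (0.44 log units; beyond the scatter), which places it on the same side of the 4-methoxyphenyl compound as the 2-fluorophenyl group, although this step changes both the group and its place on the phenyl ring. No supporting data bear on why these numbers fall as they do.

Open, from the compounds shown here alone, is whether the gap from compound 1 follows the group or its place on the ring, a question that a 2-methoxyphenyl or 4-nitrophenyl group would address. Also open, going by these compounds, is how an amine or a carboxylic acid would read at the place held by fluoro and nitro.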